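The source may hold more compounds than are shown below. What is called first, only, known or untested is meant among the compounds shown, and "the series" means these compounds.

Measured compounds:
- compound 1, `COc1ccccc1/C=c1\c(=O)[nH]/c(=C/c2ccccc2Cl)c(=O)n1C`, in a functional assay on NCI-H1975 cells (Homo sapiens) for cytotoxicity, read by CCK-8 assay, with a stated time of 72 h (on this read-out lower numbers stand for stronger inhibition and higher numbers for weaker inhibition), compound 1 gives 200 nM
- compound 2, `C=CCn1c(=O)/c(=C\c2cccc(Br)c2)[nH]c(=O)/c1=C\c1ccccc1OC`, in this assay compound 2 gives "not active" (no number reported)
- compound 3, `C=CCn1c(=O)/c(=C\c2cc(OC)c(OC)c(OC)c2)[nH]c(=O)/c1=C\c1cccc(Br)c1`, in this assay compound 3 gives "not active" (no number reported)

Only compound 1 carries a number in this assay. Compound 2 stands without one: it is reported as not active, and compound 3, the only other entry with the same N-allyl substitution, is reported the same way. Within the data shown here, no measured pair in the set differs in a single place, so no step size is available from the data, and nothing in the three entries shows what the aryl group on the non-methylated side contributes on its own.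

Compound 4, `C=CCn1c(=O)/c(=C\c2cc(Br)ccc2F)[nH]c(=O)/c1=C\c1ccccc1OC`, is compound 2 with fluoro in place of hydrogen on an aromatic carbon. One heavy atom enters, no ring, no donor or acceptor, no charge. Since compound 2 has no number, no direction can be set against a baseline; the expectation is that compound 4 stays close to where compound 2 stands, most likely again without a reportable number in this assay, with a weak signal at best.

Compound 4 is estimated at 20000 nM in this assay, expected between 3000 nM and 100000 nM if a number is obtained.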

Compound 4, half-maximal inhibitory concentration: "not active" (no number reported)
No number was reported for compound 4; there is nothing to compare the estimate with.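

In this assay compound 2 and compound 4 are both reported as not active, so no step can be read between them. No evidence on hand bears on this result. The compounds shown leave open whether the fluoro group changes activity at all, and which structural differences separate these two compounds from the measured activity of compound 1.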